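Swapping the aryl substituent on a shared core

The compounds below may be only part of what the source reports. "The series", "measured", "known", "first", "only" and "open" are said of these compounds alone.

Measured compounds:
compound 1, `COc1ccc(-c2cc(COc3ccccc3-c3nc4ccccc4s3)on2)cc1`: 22100 nM
compound 2, `FC(F)(F)C(F)(F)C(F)(F)C(F)(F)C(F)(F)C(F)(F)C(F)(F)C(F)(F)CCn1cc(COc2ccccc2-c2nc3ccccc3s2)nn1`: 19200 nM
compound 3, `c1ccc(-n2cc(COc3ccccc3-c3nc4ccccc4s3)nn2)cc1`: 26200 nM

Of the compounds shown here, three built on the same core have been tested in a functional assay on MCF7 cells (Homo sapiens) for cytotoxicity, read by MTT assay, with a stated time of 24 h; on this read-out lower numbers stand for stronger inhibition and higher numbers for weaker inhibition. Compound 1 gives 22100 nM, the second highest of the three numbers. Its nearest neighbour is compound 2, which gives 19200 nM, and the furthest is compound 3, which gives 26200 nM. Both gaps fall within the scatter, so the three compounds cannot be told apart on this read-out: nothing in the set separates one from another.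

Compound 4, `Fc1ccccc1-c1cc(COc2ccccc2-c2nc3ccccc3s2)on1`, has not yet been measured in this assay. It differs from compound 1 in one place: 2-fluorophenyl in place of 4-methoxyphenyl on an aromatic carbon. For the measured compounds named here, no step between two measured compounds matches this change, so there is no measured precedent to draw on.

Given that the three measured compounds, which differ widely in the group at this position, all sit within the scatter of one another, the step from compound 1 to compound 4 is expected to be small and to stay within the scatter, a 1.0-fold lower number from compound 1 to compound 4 (0.00 log units; within the scatter). Compound 4 is therefore estimated to give 22000 nM in this assay, with a range from 9000 nM to 50000 nM.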

Compound 4, half-maximal inhibitory concentration: 23900 nM
Compound 4: the middle estimate sits 1.1-fold (0.04 log units) below what was measured, within the range that was stated.
By their numbers in this assay, from the lowest: compounds 2, 1, 4 and 3 (each within the scatter of the next).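

In this assay, for the compounds shown here, the exchange of 4-methoxyphenyl for 2-fluorophenyl on an aromatic carbon of a five-membered aromatic ring with 1 nitrogen and 1 oxygen gives a 1.1-fold higher number from compound 1 to compound 4 (0.03 log units; within the scatter) and provides the first step in the set that changes one place alone. The earlier compounds shown here could not show this, since no two of them formed such a step; now it is seen that a group with 1 hydrogen-bond acceptor can give way to one with 0 hydrogen-bond acceptors, and a methoxy group to a fluorine on the phenyl ring, while compound 1 and compound 4 stay indistinguishable on this read-out. Nothing measured here explains why the two cannot be told apart.

Going by these compounds alone, only this one pair speaks to the position, and both of its members carry a substituted phenyl ring. Going by these compounds, it therefore stays open whether, in this assay, a phenyl ring bearing an amine or a carboxylic acid, or a longer chain in place of the ring, would give a number beyond the scatter of compound 1.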